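Methoxy to methyl on the chain carbon of compound 1

The source may report more compounds than this note shows. Statements on the series, on what has been measured and on what is new or still open speak of the compounds shown alone.

Series notes. Compound 1 `COCC(C(=O)N1CCN(c2cccc(C(F)(F)F)c2)CC1)N1C(=O)CCC1=O` in a functional assay on the whole organism (strain Swiss) with Mus musculus as the target, in the maximal electroshock model, with a stated time of 0.25 h, at a dose of 300 mg/kg by the intraperitoneal route (a lower number here means a weaker effect, a higher number a stronger effect of the compound at the dose given), gives 25%, the lower of the two numbers at hand. Compound 2 `CC(C(=O)N1CCN(c2ccc(F)cc2)CC1)N1C(=O)CCC1=O` in this assay gives 100%, a number higher than that of compound 1 by more than the scatter. Within the data shown here, no measured pair differs in one place, so no step has been measured. Compound 3 `CCC(C(=O)N1CCN(c2cccc(C(F)(F)F)c2)CC1)N1C(=O)CCC1=O` is not yet measured; it differs from compound 1 by methyl in place of methoxy on a saturated chain carbon, two bonds along the chain from an amide-type nitrogen in a ring and a carbonyl carbon. Compound 2 also carries a methyl on the saturated chain carbon but differs elsewhere as well, so it guides the direction only loosely. The step of a number 30 percentage points higher from compound 1 to compound 3 (beyond the scatter) is expected, upward and beyond the scatter. Compound 3 is expected to give 55%, within 20% to 95%.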

Compound 3, a percentage reported as activity, at one dose (the size of the read-out at that dose, not a potency): 75%
For compound 3 the middle estimate is 20 percentage points below the measured one, and the stated range covers the measured number.
By their numbers in this assay, from the lowest: compound 1; then compound 3; then compound 2.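

Among these compounds, the change of methoxy to methyl on the saturated chain carbon gives a number 50 percentage points higher from compound 1 to compound 3 (beyond the scatter) in this assay and is the first single-place step measured. With the rest of compound 1 unchanged, this position alone clearly moves the read-out at the dose given. Nothing at hand gives a reason for the size of this step.

The compounds shown leave open how the read-out responds to a longer chain such as propyl, or to a hydroxymethyl group, at this position. Going by these compounds, whether the step carries over to other cores also remains open.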